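Amide-aryl swap on a fixed chloro-aryl core

The source may hold more compounds than are shown below. What is called first, only, known or untested is meant among the compounds shown, and "the series" means these compounds.

For the measured compounds named here, compound 3 `O=C(Nc1ccc(Cl)c(-c2nnc3c(Cl)cccn23)c1)c1ccc(Cl)cc1Cl` is the one member of this set that yields a number: in a functional assay on MCF7 cells (Homo sapiens) for antiproliferative activity, read by MTT assay, with a stated time of 72 h (a higher number here means a weaker inhibitor, a lower number a stronger inhibitor), compound 3 gives 78200 nM. Compound 1 `O=C(Nc1ccc(Cl)c(-c2nnc3c(Cl)cccn23)c1)c1ccc(F)cc1Cl` reaches only a limit, > 100000 nM, in this assay. Compound 2 `O=C(Nc1ccc(Cl)c(-c2nnc3c(Cl)cccn23)c1)c1cccnc1` likewise stops at a limit, > 100000 nM. The step of an at least 1.2-fold lower number from compound 2 to compound 3 (0.10 log units; that floor lies within the scatter) and the step of an at least 1.2-fold lower number from compound 1 to compound 3 (0.10 log units; that floor lies within the scatter) are both read against the limit (the limit of > 100000 nM in this assay, at which 2 of the 3 values shown sit), so neither is sized beyond its floor. Compound 4 `O=C(Nc1ccc(Cl)c(-c2nnc3c(Cl)cccn23)c1)c1cccnc1Cl` carries 2-chloropyridin-3-yl in place of 2,4-dichlorophenyl on a carbonyl carbon. The nearest guide is the pyridine-bearing compound 2, whose value is a limit; the added chloro in compound 4 partly restores what compound 3 has. The expected step is therefore a 1.5-fold higher number from compound 3 to compound 4 (0.19 log units; within the scatter), a move back toward weaker inhibition. For compound 4 the expected value is 120000 nM, within 60000 nM to 300000 nM.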

Compound 4, half-maximal inhibitory concentration: > 100000 nM
Compound 4: no number, only a limit (the forecaster's own chance of this, stated with the estimate: 60%); the middle value is on the limit's open side.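

In this assay, 2-chloropyridin-3-yl in place of 2,4-dichlorophenyl on the carbonyl carbon gives an at least 1.2-fold higher number from compound 3 to compound 4 (0.10 log units; that floor lies within the scatter), a floor that says little about the true size of the step. Chloro on the pyridine ring of compound 2 brings no number into view, so compound 3 remains the only member with one. The steps to compound 4 from compound 1 and compound 2 cannot be read, because both ends of each are limits: the limit of > 100000 nM in this assay, at which 3 of the 4 values shown sit.

As far as these compounds go, how far the limited compounds lie past that limit stays open. Also open, from the compounds shown here alone, is whether an aminophenyl or a carboxylic acid-bearing phenyl on this carbonyl carbon would give a number.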